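The source may hold more compounds than are shown below. What is called first, only, known or untested is meant among the compounds shown, and "the series" means these compounds.

Compound 1 `CCOC(=O)C1=Cc2ccccc2OC1(OCc1cn(CC(=O)Nc2ccccc2Br)nn1)C(F)(F)F`: in a functional assay on MCF7 cells (Homo sapiens) for inhibition, read by MTT assay, with a stated time of 24 h (on this read-out lower numbers stand for stronger inhibition and higher numbers for weaker inhibition), compound 1 reaches only the limit > 150000 nM.
Compound 2 `CCOC(=O)C1=Cc2ccccc2OC1(OCc1cn(-c2ccc(F)c(Cl)c2)nn1)C(F)(F)F`: in this assay compound 2 gives 25300 nM.
Compound 3 `CCOC(=O)C1=Cc2ccccc2OC1(OCc1cn(-c2ccc([N+](=O)[O-])cc2)nn1)C(F)(F)F`: in this assay compound 3 reaches only the limit > 150000 nM.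

Compound 3 thus stands at the limit of this assay, where two of the three measured values sit (the limit of > 150000 nM in this assay, at which 2 of the 3 values shown sit). Compound 4 `CCOC(=O)C1=Cc2ccccc2OC1(OCc1cn(CC(=O)Nc2cccc(F)c2)nn1)C(F)(F)F` differs from compound 3 by ((3-fluorophenyl)carbamoyl)methyl in place of 4-nitrophenyl on an aromatic nitrogen. For the measured compounds named here, no measured step covers this exact change. The step of an at least 5.9-fold lower number from compound 1 to compound 2 (0.77 log units; beyond the scatter) shows that replacing a carbamoylmethyl-linked bromophenyl group with a directly attached halogenated phenyl lowered the number at least modestly, and the step of an at least 5.9-fold higher number from compound 2 to compound 3 (0.77 log units; beyond the scatter) shows that the 4-nitrophenyl brought the value back to the limit. Going by the values given here, compound 1, the only measured compound bearing a carbamoylmethyl-linked phenyl on the triazole nitrogen, also sits at the limit in this assay. Compound 4 is therefore expected to remain at or near the limit, and the step that the limit leaves unreadable from compound 3 to compound 4 is expected to be none beyond the scatter. Compound 4 is estimated at 200000 nM, with a range from 60000 nM to 600000 nM.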

Compound 4, half-maximal inhibitory concentration: > 150000 nM
Compound 4: only a limit was reported (the forecaster's own chance of this, stated with the estimate: 70%); the middle value is on the limit's open side.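

In this assay compound 4 reaches only a limit, > 150000 nM. For the compounds shown here, the one readable step, an at least 5.9-fold higher number from compound 2 to compound 4 (0.77 log units; beyond the scatter), shows that ((3-fluorophenyl)carbamoyl)methyl on the aromatic nitrogen does not hold the lower number seen with 3-chloro-4-fluorophenyl at this position. The steps that join compound 4 to compound 1 and compound 3 cannot be read, since limits stand at both ends, so neither the change from 2-bromophenyl to 3-fluorophenyl on the amide-type nitrogen nor the change from 4-nitrophenyl can be sized, and most of the set now rests at one limit: the limit of > 150000 nM in this assay, at which 3 of the 4 values shown sit.

As far as these compounds go, what a benzyl or an unsubstituted phenyl on this aromatic nitrogen would give remains open. So does whether the chlorine or the fluorine of the 3-chloro-4-fluorophenyl group matters more on its own, for example in a 4-fluorophenyl or a 3-chlorophenyl.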